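This account rests on a few compounds, and the source may have more. Where it says the series, first, only, none or still open, it means among the compounds named here.

Compounds measured in a functional assay on HCT-116 cells (Homo sapiens) for cytotoxicity, read by MTT assay, with a stated time of 72 h; a lower number here means a stronger inhibitor, a higher number a weaker inhibitor:
Compound 1, `COc1cccc(CNC(=O)c2nc(Br)c3cccnc3c2N[C@H]2CC[C@H](N)CC2)c1`, gives 6000 nM.
Compound 2, `N[C@H]1CC[C@H](Nc2c(C(=O)NCc3ccc(F)cc3)nc(Br)c3cccnc23)CC1`, gives 7000 nM.
Compound 3, `N[C@H]1CC[C@H](Nc2c(C(=O)Nc3ccccc3)nc(Br)c3cccnc23)CC1`, gives 2000 nM.

Compound 3 stands at the lowest number of the three in this assay, and both of its gaps to the others lie beyond the scatter, so it is the most potent of this small set. The two steps that lead into it change a benzyl group on the amide-type nitrogen to a phenyl: a 3.0-fold lower number from compound 1 to compound 3 (0.48 log units; beyond the scatter) and a 3.5-fold lower number from compound 2 to compound 3 (0.54 log units; beyond the scatter), both modest. The pair of benzyl analogues themselves sit close together, a 1.2-fold higher number from compound 1 to compound 2 (0.07 log units; within the scatter).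

Compound 4, `N[C@H]1CC[C@H](Nc2c(C(=O)NC3CCCCC3)nc(Br)c3cccnc23)CC1`, is not yet measured. It differs from compound 3 in one place: cyclohexyl in place of phenyl on an amide-type nitrogen. Within the data shown here, no measured step exchanges an aromatic ring for a saturated one on this nitrogen, so the two benzyl-to-phenyl steps bear on it only in showing that what sits on the amide-type nitrogen moves this assay by modest amounts. On that footing compound 4 is expected to land near compound 3 or somewhat weaker, with the step of a 1.8-fold higher number from compound 3 to compound 4 (0.24 log units; within the scatter) estimated as small. The estimate for compound 4 in this assay is 3500 nM, with a range from 1200 nM to 10000 nM.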

Compound 4, half-maximal inhibitory concentration: > 10000 nM
Compound 4: a limit, no number; the forecaster's own chance of this, stated with the estimate: 5%; middle value at least 2.8-fold (0.45 log units) away from the limit.
By their numbers in this assay, from the lowest: compound 3; then compounds 1 and 2 (each within the scatter of the next). At a limit, above all of these: compound 4.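

In this assay the value of compound 4 is a limit and not a number, the only such value among the compounds shown: the limit of > 10000 nM in this assay, at which 1 of the 4 values shown sits.

Cyclohexyl in place of phenyl on the amide-type nitrogen gives an at least 5.0-fold higher number from compound 3 to compound 4 (0.69 log units; beyond the scatter), so a change that keeps the six-membered carbon ring and its heavy-atom count, and alters only whether the ring is aromatic, moves this assay by an amount that clears the scatter. Compared with the benzyl analogues, the same position gives an at least 1.4-fold higher number from compound 2 to compound 4 (0.15 log units; that floor lies within the scatter) and an at least 1.6-fold higher number from compound 1 to compound 4 (0.22 log units; that floor lies within the scatter), so these two steps fix only floors and do not show how far the cyclohexyl amide lies from either of them.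

The compounds shown leave open how a smaller saturated ring such as cyclopentyl, or a cyclohexyl carrying a hydroxyl or an amine, would read in this assay on this nitrogen. They also leave open whether a phenyl carrying a fluorine or a methoxy group, or a pyridyl ring, would hold the number of compound 3 or move away from it.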